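Trimming a Diphenylmethyl Amide to a Benzyl Amide

The source may report more compounds than this note shows. Statements on the series, on what has been measured and on what is new or still open speak of the compounds shown alone.

Of the compounds shown here, three sharing one core have been measured in a functional assay on HEK293T cells for agonist activity at histamine H2 receptor (Homo sapiens), read by beta-arrestin recruitment; a lower number here means that less compound is needed, a higher number that more compound is needed for the effect. Compound 1 `Cc1nc(N)sc1CCCN/C(N)=N/C(=O)NCC(C)CCc1ccccc1` gives 355 nM. Compound 2 `Cc1nc(N)sc1CCCN/C(N)=N/C(=O)NC(c1ccccc1)c1ccccc1` gives 331 nM, the lowest of the three numbers, yet compound 1 and compound 3 `Cc1nc(N)sc1CCCN/C(N)=N/C(=S)N[C@H](C)c1ccccc1`, which gives 372 nM, both lie within the usual scatter of it, so no ordering can be read from them. Compound 4 `Cc1nc(N)sc1CCCN/C(N)=N/C(=O)NCc1ccccc1` has not yet been measured in this assay. It differs from compound 2 by hydrogen in place of phenyl on a saturated chain carbon bound to an amide-type nitrogen and an aromatic carbon, so one of the two phenyl rings of compound 2 is gone. The measured compounds differ considerably in that region and still agree in this assay. The step from compound 2 to compound 4 is therefore expected to be a 1.5-fold higher number from compound 2 to compound 4 (0.18 log units; within the scatter), small and at most modestly toward a higher number. Compound 4 is estimated at 500 nM, with a likely range from 200 nM to 1500 nM.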

Compound 4, half-maximal effective concentration: 100 nM
The estimate for compound 4 lay 5.0-fold (0.70 log units) above the measured number, outside the stated range (below it).
By their numbers in this assay, from the lowest: compound 4; then compounds 2, 1 and 3 (each within the scatter of the next).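

Taking one phenyl ring off the saturated chain carbon gives, in this assay, a 3.3-fold lower number from compound 2 to compound 4 (0.52 log units; beyond the scatter), so the second phenyl ring is not needed for the effect and less compound is needed without it. The earlier compounds shown here could not show this, as no two of them differ in one place only. Nothing measured here explains the step.

On these data alone, what remains open is how other groups on this carbon would behave. A hydroxyl group or a cyclohexyl ring in place of the hydrogen of compound 4 could move the number either way.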